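From a butenyl ether to a bromobenzyl ether

The compounds below may be only part of what the source reports. "The series", "measured", "known", "first", "only" and "open" are said of these compounds alone.

Measured so far in a functional assay on RAW264.7 cells (Mus musculus) for inhibition, read by Griess assay, with stated times of 1 h and 24 h; on this read-out higher numbers stand for weaker inhibition and lower numbers for stronger inhibition
- compound 1 `COc1cc(OC)c2c(c1)C(C(O)c1ccc(O)cc1)OC2=O` gives > 10000 nM, which is a limit of the assay
- compound 2 `CCCCOc1ccc(C(O)C2OC(=O)c3c(OC)cc(OC)cc32)cc1` gives 1800 nM
- compound 3 `C=CCCOc1ccc(C(O)C2OC(=O)c3c(OC)cc(OC)cc32)cc1` gives 1330 nM

Compound 3 stands level with compound 2: the gap, a 1.4-fold lower number from compound 2 to compound 3 (0.13 log units; within the scatter), does not separate them. Compound 1 gave no number, only a limit.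

Compound 4 `COc1cc(OC)c2c(c1)C(C(O)c1ccc(OCc3ccc(Br)cc3)cc1)OC2=O` has not yet been measured. Its difference from compound 3 is 4-bromophenyl in place of allyl on a saturated chain carbon bound to an oxygen on an aromatic ring. Cut one bond further out, this reads but-3-en-1-yl to 4-bromobenzyl.

Within the data shown here, three measured steps bear on this change. Replacing the hydrogen on the oxygen gave an at least 5.5-fold lower number from compound 1 to compound 2 (0.74 log units; beyond the scatter) with butyl and an at least 7.5-fold lower number from compound 1 to compound 3 (0.87 log units; beyond the scatter) with but-3-en-1-yl. Both are at least modest, and both start from the limit of > 10000 nM in this assay, at which 1 of the 3 values shown sits, as their reference. Compound 4 keeps a substituted oxygen, so the closer guide is the exchange of one chain for another, a 1.4-fold lower number from compound 2 to compound 3 (0.13 log units; within the scatter), which stayed within the scatter. No measured chain carries an aromatic ring, so this guide is loose.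

The expected change is therefore small and within the scatter, estimated as a 1.3-fold lower number from compound 3 to compound 4 (0.12 log units; within the scatter) in this assay. Compound 4 is estimated at 1000 nM, with an expected range from 350 nM to 3500 nM as its ends.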

Compound 4, half-maximal inhibitory concentration: 6530 nM
Compound 4: middle estimate off by 6.5-fold (0.81 log units), on the low side, outside the stated range (above it).
By their numbers in this assay, from the lowest: compounds 3 and 2 (each within the scatter of the next); then compound 4. At a limit, above all of these: compound 1.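

In this assay, this oxygen on an aromatic ring proved sensitive to the group it carries, which the exchange of one open chain for another had not revealed: a 4.9-fold higher number from compound 3 to compound 4 (0.69 log units; beyond the scatter) and a 3.6-fold higher number from compound 2 to compound 4 (0.56 log units; beyond the scatter) are both modest steps beyond the scatter. The 4-bromobenzyl group therefore did not behave as one more chain in the way butyl and but-3-en-1-yl did, and the advantage over hydrogen on that oxygen is no longer established, with an at least 1.5-fold lower number from compound 1 to compound 4 (0.18 log units; that floor lies within the scatter) giving a floor that lies within the scatter. Compound 1 gives a limit and not a number, so this last step has no measured size: the limit of > 10000 nM in this assay, at which 1 of the 4 values shown sits.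

The compounds shown do not separate the share of the aromatic ring from that of the bromine, a question that an unsubstituted benzyl or a 4-chlorobenzyl group on the same oxygen would address. On these data alone, how a longer chain or an amine in that place would read in this assay also remains open.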